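The source may report more compounds than this note shows. Statements on the series, on what has been measured and on what is new or still open speak of the compounds shown alone.

Working notes on the series. Compound 1 `COc1ccc(CNc2ncc(C(=O)O)c3nc(-c4ccco4)nn23)cc1OC` gives 958 nM in an assay on CHO cells for displacement of a labelled ligand from adenosine receptor A1 (Homo sapiens); on this read-out higher numbers stand for weaker inhibition and lower numbers for stronger inhibition. Compound 3 `CCOC(=O)c1cnc(NC2CC2)n2nc(-c3ccco3)nc12` gives 60.7 nM in this assay, the lowest of the two numbers shown, with compound 1 standing beyond the scatter above it. Compound 2 `O=C(Nc1ncc(C(=O)O)c2nc(-c3ccco3)nn12)NC1CCCCC1` reaches only a limit in this assay, > 100000 nM, which is a limit of the assay and not a number (the limit of > 100000 nM in this assay, at which 1 of the 3 values shown sits).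

Compound 4 `CCOC(=O)c1cnc(NCC2CCCCC2)n2nc(-c3ccco3)nc12` differs from compound 3 by cyclohexylmethyl in place of cyclopropyl on a nitrogen on an aromatic ring. Among the measured compounds shown here, no pair of measured compounds shows this change, so the expected step of a 1.5-fold lower number from compound 3 to compound 4 (0.18 log units; within the scatter) is estimated as small, either within the scatter or a modest shift to a lower number. Compound 4 is estimated at 40 nM, with a range from 10 nM to 200 nM.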

Compound 4, inhibition constant: 432 nM
Compound 4: the middle estimate sits 11-fold (1.03 log units) below what was measured; measured number outside the range, above it.
By their numbers in this assay, from the lowest: compound 3; then compound 4; then compound 1. At a limit, above all of these: compound 2.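

In this assay, cyclohexylmethyl in place of cyclopropyl on a nitrogen on an aromatic ring gives a 7.1-fold higher number from compound 3 to compound 4 (0.85 log units; beyond the scatter). Among the compounds shown here, this is the first one-place comparison, and it shows that this position responds to the group it carries, with cyclopropyl giving the lower number of the two. No measurement shown gives a cause for this step.

Still open, as far as these compounds go, is how a phenyl ring or an open chain such as n-butyl on this nitrogen would read. Also open, from the compounds shown here alone, is whether the same change gives a similar step in compounds carrying the carboxylic acid.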